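Methoxymethyl to isopropoxymethyl on compound 2

A few compounds are considered here, and "the series" means these few. Any claim that something is new, unique, unknown or untested is made for them only; others in the source may bear on it.

compound 1 `COCc1cc(CN2CCCC2)c(O)c2ncccc12` gives 52500 nM
compound 2 `COCc1cc(CN2CCCCC2)c(O)c2ncccc12` gives 22400 nM

In a functional assay on A-431 cells (Homo sapiens) for inhibition, with a stated time of 72 h (on this read-out lower numbers stand for stronger inhibition and higher numbers for weaker inhibition), compound 2 has the lower of the two numbers at 22400 nM and is the stronger inhibitor of this pair. Compound 3 `CC(C)OCc1cc(CN2CCCCC2)c(O)c2ncccc12` differs from compound 2 in one place, with isopropyl in place of methyl on an oxygen on a saturated carbon. Among the compounds with values here, only one measured step exists, a 2.3-fold lower number from compound 1 to compound 2 (0.37 log units; beyond the scatter) and it swaps pyrrolidin-1-yl for piperidin-1-yl elsewhere in the molecule. Within the data shown here, no measured pair tests the new change directly, so that modest step offers only a rough guide to size. A small shift toward a lower number in this assay is expected, possibly none beyond the scatter. The estimated change is a 1.4-fold lower number from compound 2 to compound 3 (0.15 log units; within the scatter) for this single swap. For compound 3 the expected value is 16000 nM with an estimated range from 6000 nM to 42000 nM in this assay for now.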

Compound 3, half-maximal inhibitory concentration: 7410 nM
Beside the measured number, compound 3's estimate is 2.2-fold (0.33 log units) above it; the measured number falls inside the stated range.
By their numbers in this assay, from the lowest: compound 3; then compound 2; then compound 1.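

In this assay, isopropyl in place of methyl on an oxygen on a saturated carbon gives a 3.0-fold lower number from compound 2 to compound 3 (0.48 log units; beyond the scatter), which shows that this position also affects the read-out, not only the site of the piperidin-1-yl group. The swap adds only carbon atoms and leaves the count of hydrogen-bond donors and acceptors unchanged, yet the number still falls beyond the scatter. Nothing available here explains this step.

As far as these compounds go, it remains open whether the number keeps falling with a larger group on that oxygen, such as tert-butyl or cyclohexyl, or whether it rises again with a longer chain carrying an amine. From the compounds shown here alone, it is also open whether the same swap would lower the number to a similar extent with pyrrolidin-1-yl in place of piperidin-1-yl.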